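The compounds below may be only part of what the source reports. "The series", "measured", "known", "first", "only" and "open" are said of these compounds alone.

Measured values in an ADME assay on SH-SY5Y cells (Homo sapiens) for cytotoxicity, read by MTT assay, with a stated time of 72 h; a higher number here means a weaker inhibitor, a lower number a stronger inhibitor
compound 1 `O=C(CN1CCN(C(=O)c2ccc(Br)cc2)CC1)N1CCN(CCCc2c[nH]c3ccccc23)CC1` gives 59300 nM
compound 2 `O=C(CN1CCN(C(=O)c2ccccc2)CC1)N1CCN(CCCc2c[nH]c3ccc(F)cc23)CC1` gives 146000 nM
compound 3 `COc1ccc(C(=O)N2CCN(CC(=O)N3CCN(CCCc4c[nH]c5ccc(F)cc45)CC3)CC2)cc1` gives 161000 nM

In this assay compound 3 sits level with compound 2, and both stand at higher numbers than compound 1. Compound 4 `O=C(CN1CCN(C(=O)c2ccc(Br)cc2)CC1)N1CCN(CCCc2c[nH]c3ccc(F)cc23)CC1` has not been measured yet. It differs from compound 3 by one change on an aromatic carbon, para to a large group: bromo in place of methoxy on an aromatic carbon is the whole difference.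

Among the measured compounds shown here, only one measured step touches this place: a 1.1-fold higher number from compound 2 to compound 3 (0.04 log units; within the scatter) for methoxy in place of hydrogen. For the measured compounds named here, that step is small, but no measured step swaps methoxy for bromo directly. Compound 1 also carries 4-bromophenyl and gives 59300 nM but differs from compound 4 in the core as well, so that number cannot be credited to bromo alone. A modest move toward lower numbers is therefore expected. The estimated change is a 1.6-fold lower number from compound 3 to compound 4 (0.21 log units; within the scatter) and no larger step is expected. In this assay compound 4 is estimated at 100000 nM with a range of 55000 nM to 170000 nM around that middle.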

Compound 4, half-maximal inhibitory concentration: 47400 nM
Compound 4: the middle estimate sits 2.1-fold (0.32 log units) above what was measured; the measured number lies below the stated range.
By their numbers in this assay, from the lowest: compounds 4 and 1 (each within the scatter of the next); then compounds 2 and 3 (each within the scatter of the next).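

In this assay, hydrogen and methoxy at this place on the ring could not be told apart (a 1.1-fold higher number from compound 2 to compound 3 (0.04 log units; within the scatter)), so the position looked as if it hardly mattered. Bromo shows that it can matter, as it stands clearly apart from both methoxy (a 3.4-fold lower number from compound 3 to compound 4 (0.53 log units; beyond the scatter)) and hydrogen (a 3.1-fold lower number from compound 2 to compound 4 (0.49 log units; beyond the scatter)) on the same fluoro-bearing core. With 4-bromophenyl in place, fluoro in place of hydrogen on the other aromatic part makes no difference beyond the scatter (a 1.3-fold lower number from compound 1 to compound 4 (0.10 log units; within the scatter)), and nothing here explains the effect of bromo.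

From the compounds shown here alone, whether chloro, iodo, an amine or a carboxylic acid at this place would group with bromo or with methoxy remains open. So does whether the step from methoxy to bromo would keep its size on the core without fluoro.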